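The source may report more compounds than this note shows. Statements on the series, on what has been measured and on what is new or still open speak of the compounds shown alone.

Compound 1 `O=c1c(Cc2coc3cccc(OCC4CCCCC4)c3c2=O)coc2ccccc12` — 4230 nM
Compound 2 `O=c1c(Cc2coc3cccc(OCC4CCCCC4)c3c2=O)coc2cc(Cl)ccc12` — > 10000 nM (a limit of the assay, not a number)
Compound 3 `COc1ccc2c(=O)c(Cc3coc4cccc(OCC5CCCCC5)c4c3=O)coc2c1` — 1350 nM

These three compounds share one core and differ only in what sits on a single aromatic carbon of one outer ring. In a functional assay on ACHN cells (Homo sapiens) for antiproliferative activity, read by XTT assay (on this read-out higher numbers stand for weaker inhibition and lower numbers for stronger inhibition), compound 1 gives 4230 nM. Compound 2 reaches only the limit of this assay, > 10000 nM. Compound 3 gives 1350 nM, the lowest of the two real numbers shown, its nearest neighbour being compound 1, and the step of a 3.1-fold lower number from compound 1 to compound 3 (0.50 log units; beyond the scatter) lies beyond the scatter. The other two steps are an at least 2.3-fold higher number from compound 1 to compound 2 (0.37 log units; beyond the scatter) and an at least 7.4-fold lower number from compound 2 to compound 3 (0.86 log units; beyond the scatter).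

Compound 4 `Cc1ccc2c(=O)c(Cc3coc4cccc(OCC5CCCCC5)c4c3=O)coc2c1` has not been measured. It differs from compound 3 by methyl in place of methoxy on an aromatic carbon. Among the compounds with values here, no measured step exchanges methyl for methoxy directly. The nearest guidance is that putting methoxy in place of hydrogen lowered the number (a 3.1-fold lower number from compound 1 to compound 3 (0.50 log units; beyond the scatter)) and putting methoxy in place of chloro lowered it further (an at least 7.4-fold lower number from compound 2 to compound 3 (0.86 log units; beyond the scatter)), so the methoxy appears to be the favourable group at this carbon among those tried. Taking it away in favour of methyl is therefore expected to raise the number modestly: a 2.2-fold higher number from compound 3 to compound 4 (0.35 log units; beyond the scatter). For compound 4 in this assay the estimate is 3000 nM, with a likely range from 1000 nM to 10000 nM.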

Compound 4, half-maximal inhibitory concentration: 2250 nM
Compound 4: the middle estimate sits 1.3-fold (0.12 log units) above what was measured; measured number inside the range.
By their numbers in this assay, from the lowest: compounds 3, 4 and 1 (each within the scatter of the next, the first and the last beyond it). At a limit, above all of these: compound 2.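

In this assay, methyl in place of methoxy gives a 1.7-fold higher number from compound 3 to compound 4 (0.22 log units; within the scatter), so the heavy atom and hydrogen-bond acceptor that leave with the methoxy are not shown to matter at this carbon, and methoxy no longer looks like a unique choice. Methyl in place of hydrogen gives a 1.9-fold lower number from compound 1 to compound 4 (0.27 log units; within the scatter), so the clear separation between hydrogen and methoxy is not repeated between hydrogen and methyl, and compound 4 cannot be told apart from either compound 1 or compound 3. Only chloro stands clearly apart from methyl, with an at least 4.4-fold lower number from compound 2 to compound 4 (0.64 log units; beyond the scatter), and this step is only a bound because compound 2 rests on a limit of the assay, not a number: the limit of > 10000 nM in this assay, at which 1 of the 4 values shown sits.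

Still open, from the compounds shown here alone, is how this carbon responds to other groups, such as an amine, a carboxylic acid, or a longer chain like ethoxy. The compounds shown also cannot tell whether methyl or methoxy would give a similar result on another carbon of the same ring, and they offer no explanation for the result with chloro.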